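A Methyl Added to the Benzyl of Compound 1

The source may report more compounds than this note shows. Statements on the series, on what has been measured and on what is new or still open speak of the compounds shown alone.

Compound 1 `Cc1cc(Nc2ccn(Cc3ccccc3)n2)n2nc(SCc3ccc(Br)cc3)nc2n1`: > 50000 nM
Compound 2 `COc1ccc(CSc2nc3nc(C)cc(Nc4cc(-c5ccccc5)[nH]n4)n3n2)cc1`: 8110 nM
Compound 3 `Cc1cc(Nc2cc(-c3ccccc3)[nH]n2)n2nc(SCc3csc4ccccc34)nc2n1`: 4420 nM

In a functional assay on PC-9 cells (Homo sapiens) for inhibition, read by MTT assay, with a stated time of 72 h (on this read-out lower numbers stand for stronger inhibition and higher numbers for weaker inhibition), compound 1 gives > 50000 nM and this is a limit, not a number. Compound 1 therefore stands at the limit of > 50000 nM in this assay, at which 1 of the 3 values shown sits, and has no exact value to start from.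

The next structure is compound 4 `Cc1ccc(Cn2ccc(Nc3cc(C)nc4nc(SCc5ccc(Br)cc5)nn34)n2)cc1`, in which a benzyl becomes a 4-methylbenzyl. The change is methyl in place of hydrogen on an aromatic carbon and amounts to methyl in place of hydrogen on an aromatic carbon.

For the measured compounds named here, only one measured step offers any guide: a 1.8-fold lower number from compound 2 to compound 3 (0.26 log units; within the scatter). That exchange lies at a different place in the molecule, so it bears on this change only loosely. With that single step as a guide, no change beyond the scatter is expected in this assay, and a second limit would be no surprise.

The expected step is a number no higher from compound 1 to compound 4 (the limit leaves the size open) as an estimate.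

Compound 4 is estimated at 50000 nM, with an expected range from 20000 nM to 100000 nM as the outcome.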

Compound 4, half-maximal inhibitory concentration: > 50000 nM
Compound 4: a limit, no number; the forecaster's own chance of this, stated with the estimate: 70%; the middle value sits exactly at the limit.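

In this assay, for the compounds shown here, compound 1 and compound 4 each give only a limit, so no step between them can be read: the limit of > 50000 nM in this assay, at which 2 of the 4 values shown sit.

On these data alone, whether the 4-methylbenzyl of compound 4 changes inhibition at all compared with the benzyl of compound 1 stays open, as does the true strength of either compound.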